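The source may report more compounds than this note shows. Statements on the series, on what has been measured and on what is new or still open speak of the compounds shown alone.

Compound 1 `CCCCOc1ccc(NC(=O)n2nc(N)c3ccccc32)cc1` is tested in a functional assay on MOLT-4 cells (Homo sapiens) for inhibition, read by sulforhodamine B assay, with a stated time of 48 h (a higher number here means a weaker inhibitor of growth, a lower number a stronger inhibitor of growth), where compound 1 gives 4480 nM. Going by the values given here, that is the lower of the two numbers measured so far; compound 2 `Nc1nn(C(=O)Nc2c(F)cccc2F)c2ccccc12` gives 32700 nM in this assay. Among the compounds with values here, no two measured compounds differ in only one place, so no single step has been charted. Compound 3 `Nc1nn(C(=O)Nc2ccc(Cc3ccccc3)cc2)c2ccccc12` differs from compound 1 as follows: benzyl in place of butoxy on an aromatic carbon. Within the data shown here, with no comparable step measured, the change a 1.1-fold higher number from compound 1 to compound 3 (0.05 log units; within the scatter) is expected to be small, in either direction or none beyond the scatter. Compound 3 is therefore estimated at 5000 nM, with a range from 1500 nM to 16000 nM.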

Compound 3, concentration for 50% growth inhibition: 636 nM
Compound 3: the middle estimate sits 7.9-fold (0.90 log units) above what was measured; the measured number lies below the stated range.
By their numbers in this assay, from the lowest: compound 3; then compound 1; then compound 2.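

In this assay, the group on this aromatic carbon, para to a large group, clearly affects the read-out: benzyl in place of butoxy gives a 7.0-fold lower number from compound 1 to compound 3 (0.85 log units; beyond the scatter). This single change swaps an open chain holding an oxygen for a carbon-only group carrying an aromatic ring, and the number falls. Nothing measured here bears on why it falls. Going by these compounds, it remains open whether a phenoxy group, which keeps an oxygen and adds a ring, or a plain pentyl chain would behave like benzyl. The effects of the ring and of losing the oxygen therefore cannot yet be separated.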